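Swapping a Urea Arm for an Aryl Amide

A few compounds are considered here, and "the series" means these few. Any claim that something is new, unique, unknown or untested is made for them only; others in the source may bear on it.

Measured in a functional assay on HUVEC cells (Homo sapiens) for inhibition, with stated times of 2 h and 72 h; on this read-out lower numbers stand for stronger inhibition and higher numbers for weaker inhibition:
- compound 1 `COc1cc2nccc(Oc3ccc4c(NC(=O)Nc5ccc(C(F)(F)F)cc5Cl)nn(C)c4c3)c2cc1OC`: 1150 nM
- compound 2 `COc1cc2nccc(Oc3ccc4c(NC(=O)c5cc(Cl)ccn5)nn(C)c4c3)c2cc1OC`: 27 nM
- compound 3 `COc1ccc(NC(=O)Nc2nn(C)c3cc(Oc4ccnc5cc(OC)c(OC)cc45)ccc23)cc1`: 7 nM

Compound 1 has the highest number of the three, which makes it the weakest inhibitor in this small set. Compound 4 `COc1cc2nccc(Oc3ccc4c(NC(=O)c5ccc(C(F)(F)F)cc5)nn(C)c4c3)c2cc1OC` differs from it as follows: 4-(trifluoromethyl)phenyl in place of (2-chloro-4-(trifluoromethyl)phenyl)amino on a carbonyl carbon. In short, 4-(trifluoromethyl)phenyl stands in place of (2-chloro-4-(trifluoromethyl)phenyl)amino on a carbonyl carbon.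

Among the compounds with values here, two measured steps bear on this change. The closer one is a 43-fold lower number from compound 1 to compound 2 (1.63 log units; beyond the scatter), as it replaces the same group at the same place. The other is a 160-fold lower number from compound 1 to compound 3 (2.22 log units; beyond the scatter), which shows that changing only the aromatic end can also bring a large drop. Neither step tests the ring that enters compound 4, so the size remains uncertain. In this assay, a large step towards a lower number is therefore expected, though probably smaller than either precedent. The expected change is a 12-fold lower number from compound 1 to compound 4 (1.06 log units; beyond the scatter). For compound 4 the estimated value is 100 nM, with an expected range from 20 nM to 500 nM.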

Compound 4, half-maximal inhibitory concentration: 79 nM
The estimate for compound 4 lay 1.3-fold (0.10 log units) above the measured number, and the stated range covers the measured number.
By their numbers in this assay, from the lowest: compound 3; then compound 2; then compound 4; then compound 1.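

In this assay, the step of a 15-fold lower number from compound 1 to compound 4 (1.16 log units; beyond the scatter) shows that a large drop at this carbonyl carbon does not depend on the 4-chloropyridin-2-yl group of compound 2 or on the (4-methoxyphenyl)amino group of compound 3: a carbon-only 4-(trifluoromethyl)phenyl ring also gives one. That ring still falls short of both groups, with a 2.9-fold higher number from compound 2 to compound 4 (0.47 log units; beyond the scatter) and an 11-fold higher number from compound 3 to compound 4 (1.05 log units; beyond the scatter), so the choice of group here continues to matter after the large drop. No measured evidence accounts for these differences.

This change removes the chlorine and the nitrogen together, so the compounds shown cannot tell which loss carries the step; a (4-(trifluoromethyl)phenyl)amino group on the same carbonyl carbon would separate them. Going by these compounds, how an amine or a carboxylic acid on this ring would fare also remains open.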